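The source may report more compounds than this note shows. Statements on the series, on what has been measured and on what is new or still open speak of the compounds shown alone.

Compound 1, with the structure `COc1ccc(C(=O)/C=C/c2cc(-c3cc(OC)c(OC)c(OC)c3)n[nH]2)cc1OC`, is one of three close relatives tested in a functional assay on K562 cells (Homo sapiens) for cytotoxicity, read by sulforhodamine B assay, with a stated time of 48 h, tested at 0.01 uM; a higher number here means a weaker effect of the compound at the concentration tested, a lower number a stronger effect. In that assay compound 1 gives 96%, the lowest of the three numbers, yet all three sit within the scatter of each other, so no ordering can be read from them. Compound 2, `COc1ccc(C(=O)/C=C/c2cc(-c3cc(OC)c(OC)c(OC)c3)n[nH]2)cc1`, gives 97%, and the step of a number 1 percentage points higher from compound 1 to compound 2 (within the scatter). Compound 3, `COc1cc(-c2cc(/C=C/C(=O)c3ccc(F)c(F)c3)[nH]n2)cc(OC)c1OC`, gives 100%, with a number 4 percentage points higher from compound 1 to compound 3 (within the scatter) and a number 3 percentage points higher from compound 2 to compound 3 (within the scatter).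

The unmeasured compound 4, `COc1cc(C(=O)/C=C/c2cc(-c3cc(OC)c(OC)c(OC)c3)n[nH]2)cc(OC)c1OC`, differs from compound 1 in a single place: methoxy in place of hydrogen on an aromatic carbon. Within the data shown here, the steps that bear on this change are the two that alter the same aryl ring attached to the carbonyl. Removing a methoxy from that ring left the number unchanged beyond the scatter, as did exchanging the whole ring for a difluorophenyl. Adding a third methoxy to that ring is therefore expected to leave the number where it is, with no step beyond the scatter in either direction in this assay.

Compound 4 is thus estimated at 96%, in a range from 88% to 103%, which corresponds to an expected step of no change at the digits printed from compound 1 to compound 4 (within the scatter).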

Compound 4, a percentage reported as activity, at one concentration (the size of the read-out at that concentration, not a potency): 99%
For compound 4 the middle estimate is 3 percentage points below the measured one, within the range that was stated.
By their numbers in this assay, from the lowest: compounds 1, 2, 4 and 3 (each within the scatter of the next).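

In this assay, the new methoxy, placed ortho to a methoxy group and meta to a large group, gives a number 3 percentage points higher from compound 1 to compound 4 (within the scatter). The earlier compounds shown here showed only what happened when a methoxy was removed from this aryl ring or the whole ring was replaced; this result adds the opposite change, a methoxy entering at a position that held hydrogen, and it too produces no step beyond the scatter. Nothing measured here explains this outcome.

The compounds shown leave open whether a different kind of group at this position, such as an amine, a carboxylic acid or a longer chain in place of the methoxy, would give a step beyond the scatter. Since all four numbers come from one low concentration and lie within the scatter of each other, they also leave open whether compound 1 and compound 4 would differ at a concentration where the cells respond more clearly.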